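Swapping the Pyrazole Back for a Fluorinated Phenyl Ring

The source may hold more compounds than are shown below. What is called first, only, known or untested is meant among the compounds shown, and "the series" means these compounds.

Compound 1, `COc1ccc(C2=Nc3c(C(C)(C)C)nn(CCCO)c3C(=O)NC2)cc1-c1ccccc1F`: 0.8 h
Compound 2, `COc1ccc(C2=Nc3c(C(C)(C)C)nn(CCCO)c3C(=O)NC2)cc1-c1ccccc1SC`: 0.85 h
Compound 3, `COc1ccc(C2=Nc3c(C(C)(C)C)nn(CCCO)c3C(=O)NC2)cc1-c1cnn(C)c1`: 2 h

All three share one core and were tested in an ADME assay on microsomes from liver (Homo sapiens) for metabolic stability; on this read-out lower numbers stand for a shorter-lived compound and higher numbers for a longer-lived compound. Compound 3 stands highest of the three: the steps of a 2.5-fold higher number from compound 1 to compound 3 (0.40 log units; beyond the scatter) and a 2.4-fold higher number from compound 2 to compound 3 (0.37 log units; beyond the scatter) both lie beyond the scatter, whereas a 1.1-fold higher number from compound 1 to compound 2 (0.03 log units; within the scatter) does not. The next compound, compound 4, `COc1ccc(C2=Nc3c(C(C)(C)C)nn(CCCO)c3C(=O)NC2)cc1-c1ccc(F)cc1F`, differs from compound 3 in one place: 2,4-difluorophenyl in place of 1-methyl-1H-pyrazol-4-yl on an aromatic carbon. This returns a six-membered carbon ring of the kind carried by compound 1 and compound 2, so the two steps that raised the number toward compound 3 are the ones that bear on it, now run backwards. Compound 4 is therefore expected to fall by about a 2.4-fold lower number from compound 3 to compound 4 (0.37 log units; beyond the scatter) in this assay. The estimated half-life of compound 4 is 0.85 h, within a range from 0.45 h to 1.6 h.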

Compound 4, half-life: 2 h
For compound 4 the middle estimate is 2.4-fold (0.37 log units) below the measured one; the measured number lies above the stated range.
By their numbers in this assay, from the lowest: compounds 1 and 2 (each within the scatter of the next); then compounds 3 and 4 (each within the scatter of the next).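

In this assay the step of no change at the digits printed from compound 3 to compound 4 (within the scatter) shows that a carbon-only aromatic ring at this position can hold the half-life level with 1-methyl-1H-pyrazol-4-yl. The carbon ring alone therefore does not set the lower numbers, since the gain is a 2.5-fold higher number from compound 1 to compound 4 (0.40 log units; beyond the scatter) when one more fluoro is added and a 2.4-fold higher number from compound 2 to compound 4 (0.37 log units; beyond the scatter) when 2,4-difluorophenyl replaces 2-(methylsulfanyl)phenyl. No supporting measurement explains these differences.

From the compounds shown here alone, whether a nitrile or a trifluoromethyl group on this phenyl ring would keep the half-life at this level remains open. So does the effect of a pyridine ring at the same position.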